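Fluorinated Aryl Urea Triazolylpyridines Tested Against Breast Cancer Cells

The source may hold more compounds than are shown below. What is called first, only, known or untested is meant among the compounds shown, and "the series" means these compounds.

The measured compounds:
- compound 1, `CN(C)CCn1cnnc1-c1cc(Oc2ccc(NC(=O)Nc3ccccc3C(F)(F)F)cc2F)ccn1`: > 50000 nM
- compound 2, `CN(C)CCn1cnnc1-c1cc(Oc2ccc(NC(=O)Nc3ccc(F)c(F)c3)cc2F)ccn1`: > 50000 nM
- compound 3, `CN(C)CCCn1cnnc1-c1cc(Oc2ccc(NC(=O)Nc3ccccc3C(F)(F)F)cc2F)ccn1`: 40500 nM

Three compounds built on one shared core were tested in a functional assay on MDA-MB-231 cells (Homo sapiens) for antiproliferative activity, read by MTT assay, with a stated time of 72 h; on this read-out higher numbers stand for weaker inhibition and lower numbers for stronger inhibition. In this assay compound 1 gives > 50000 nM, which is a limit of the assay and not a number. Compound 2 likewise gives > 50000 nM, again a limit rather than a number. Among the compounds with values here, compound 3 is the only one that yields a number, 40500 nM.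

The cores of compound 1 and compound 3 differ in one place: (dimethylamino)methyl in place of dimethylamino on a saturated chain carbon, two bonds along the chain from an aromatic nitrogen. That step is an at least 1.2-fold lower number from compound 1 to compound 3 (0.09 log units; that floor lies within the scatter); its floor sits within the scatter, so the two compounds cannot be ordered.

The change from compound 1 to compound 2 is 3,4-difluorophenyl in place of 2-(trifluoromethyl)phenyl on an amide-type nitrogen. Its step is a step that the two limits leave unreadable from compound 1 to compound 2, since both values rest at the limit of > 50000 nM in this assay, at which 2 of the 3 values shown sit.

The same change is now made on compound 3, giving compound 4, `CN(C)CCCn1cnnc1-c1cc(Oc2ccc(NC(=O)Nc3ccc(F)c(F)c3)cc2F)ccn1`: 3,4-difluorophenyl in place of 2-(trifluoromethyl)phenyl on an amide-type nitrogen. The two place lines read alike, so this is the same change on a different core. Its expected size cannot be read from the pair compound 1 to compound 2, since both sit at a limit. Given that compound 3 gives 40500 nM, the expected step of a 1.4-fold higher number from compound 3 to compound 4 (0.13 log units; within the scatter) is small. Compound 4 is therefore expected to return only a limit. The estimate for compound 4 is 55000 nM, spanning 25000 nM to 120000 nM.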

Compound 4, half-maximal inhibitory concentration: 25300 nM
Compound 4: middle estimate off by 2.2-fold (0.34 log units), on the high side, within the range that was stated.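

In this assay, the swap of 2-(trifluoromethyl)phenyl for 3,4-difluorophenyl on the amide-type nitrogen gives a 1.6-fold lower number from compound 3 to compound 4 (0.20 log units; within the scatter) and so does not separate the two compounds, while the same swap on the core of compound 1 cannot be read. The exchange of dimethylamino for (dimethylamino)methyl on the chain can now be set beside its earlier reading, with an at least 1.9-fold lower number from compound 2 to compound 4 (0.29 log units; that floor lies within the scatter) as the new step, and the comparison stands thus: the same change on two cores in this assay, an at least 1.2-fold lower number (0.09 log units; that floor lies within the scatter) from compound 1 to compound 3 and an at least 1.9-fold lower number (0.29 log units; that floor lies within the scatter) from compound 2 to compound 4; the limit leaves it open whether they differ. This shows that neither reading of the chain exchange rises beyond the scatter, but it does not show that the exchange carries over from one core to the other with the same size, and the true size of either step stays hidden behind the limit: the limit of > 50000 nM in this assay, at which 2 of the 4 values shown sit.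

The compounds shown leave open whether a longer chain, or a carboxylic acid in place of the dimethylamino group, would give a number clearly apart from those seen here. They also leave open how an unsubstituted phenyl on the amide-type nitrogen would read on the core of compound 3.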